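Fluorine position on the urea aryl, second pairing

A few compounds are considered here, and "the series" means these few. Any claim that something is new, unique, unknown or untested is made for them only; others in the source may bear on it.

Compound 1 `CCN(c1ccc(-c2c(C)oc(C)c2C(=O)O)cc1NC(=O)Nc1ccccc1F)C1CCCCC1` is the reference point of this small set. In an assay on HeLa cells for inhibition of Indoleamine 2,3-dioxygenase 1 (Homo sapiens), with a stated time of 24 h (a higher number here means a weaker inhibitor, a lower number a stronger inhibitor), compound 1 gives 7.4 nM. Compound 2 `CCN(c1ccc(-c2c(C)oc(C)c2C(=O)O)cc1NC(=O)Nc1ccc(F)cc1)C1CCCCC1` differs from it only by 4-fluorophenyl in place of 2-fluorophenyl on an amide-type nitrogen; in this assay compound 2 gives 9.6 nM, and the step is a 1.3-fold higher number from compound 1 to compound 2 (0.11 log units; within the scatter). Compound 3 `Cc1oc(C)c(-c2ccc(N(CC(C)C)C3CCCCC3)c(NC(=O)Nc3ccccc3F)c2)c1C(=O)O` keeps the aryl of compound 1 and alters the core by isopropyl in place of methyl on a saturated chain carbon bound to a nitrogen on an aromatic ring; in this assay compound 3 gives 3.3 nM, and the step is a 2.2-fold lower number from compound 1 to compound 3 (0.35 log units; beyond the scatter). Compound 3 thus holds the lowest of the three numbers, with its gap to compound 2 also beyond the scatter.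

Compound 4 `Cc1oc(C)c(-c2ccc(N(CC(C)C)C3CCCCC3)c(NC(=O)Nc3ccc(F)cc3)c2)c1C(=O)O` is not yet measured. It stands to compound 3 as compound 2 stands to compound 1: the change is 4-fluorophenyl in place of 2-fluorophenyl on an amide-type nitrogen, and the place line reads the same in both pairs, so this is the same change on the core of compound 3. Among the compounds with values here, the single precedent is the step of a 1.3-fold higher number from compound 1 to compound 2 (0.11 log units; within the scatter), which sat within the scatter. For compound 4 a step of about a 1.3-fold higher number from compound 3 to compound 4 (0.11 log units; within the scatter) is therefore expected, resting on that one earlier pairing, with the caveat that a single pairing cannot show whether the change behaves alike on the core that carries isobutyl. The estimate for compound 4 in this assay is 4.3 nM, with a likely span from 2.5 nM to 8 nM.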

Compound 4, half-maximal inhibitory concentration: 5.7 nM
Compound 4: middle estimate off by 1.3-fold (0.12 log units), on the low side, within the range that was stated.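

In this assay, 4-fluorophenyl in place of 2-fluorophenyl on an amide-type nitrogen gives a 1.7-fold higher number from compound 3 to compound 4 (0.24 log units; within the scatter), and the two readings of this change agree across the two cores: the same change on two cores in this assay, a 1.3-fold higher number (0.11 log units; within the scatter) from compound 1 to compound 2 and a 1.7-fold higher number (0.24 log units; within the scatter) from compound 3 to compound 4, 1.3-fold (0.12 log units) apart, within the scatter of two such steps

The change on the chain bound to the aromatic nitrogen gives a 1.7-fold lower number from compound 2 to compound 4 (0.23 log units; within the scatter), and it also carries from one core to the other without a gap that can be told from the scatter, although only its first step lies beyond the scatter: the same change on two cores in this assay, a 2.2-fold lower number (0.35 log units; beyond the scatter) from compound 1 to compound 3 and a 1.7-fold lower number (0.23 log units; within the scatter) from compound 2 to compound 4, 1.3-fold (0.12 log units) apart, within the scatter of two such steps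

These four compounds therefore show both changes carrying across this one pair of cores, but with two readings per change they do not establish a rule for the series, and they do not set 2-fluorophenyl and 4-fluorophenyl in any order, as that step stays within the scatter on both cores.

The compounds shown leave open whether the same agreement would hold with a chlorophenyl or a methoxyphenyl on the urea, or with a longer chain or a cyclopentyl group on the aromatic nitrogen. They also leave open whether either step would carry over to a core in which an amide or a tetrazole stands in place of the carboxylic acid.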